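This account rests on a few compounds, and the source may have more. Where it says the series, first, only, none or still open, it means among the compounds named here.

Measured compounds in an assay on CHO cells for antagonist activity at transient receptor potential cation channel subfamily V member 1 (Homo sapiens), read by FLIPR; on this read-out lower numbers stand for stronger inhibition and higher numbers for weaker inhibition:
- compound 1 `CC(C(=O)NCc1ccc(C(F)(F)F)cc1N1CCN(C2CCCCC2)CC1)c1ccc(NS(C)(=O)=O)c(F)c1`: 13.8 nM
- compound 2 `CC(C(=O)NCc1ccc(C(F)(F)F)cc1N1CCN(c2ccccc2)CC1)c1ccc(NS(C)(=O)=O)c(F)c1`: 2 nM
- compound 3 `Cc1cccc(N2CCN(c3cc(C(F)(F)F)ccc3CNC(=O)C(C)c3ccc(NS(C)(=O)=O)c(F)c3)CC2)c1`: 1.8 nM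

Compound 3 holds the lowest number of the three, but its gap to compound 2 lies within the scatter; only compound 1 stands clearly apart, with a 7.7-fold lower number from compound 1 to compound 3 (0.88 log units; beyond the scatter). The aromatic ring on the piperazine nitrogen is what separates compound 1 from the other two, as a 6.9-fold lower number from compound 1 to compound 2 (0.84 log units; beyond the scatter) also shows. Adding a substituent to that ring, a 1.1-fold lower number from compound 2 to compound 3 (0.05 log units; within the scatter), changed nothing beyond the scatter.

Compound 4 `COc1ccc(N2CCN(c3cc(C(F)(F)F)ccc3CNC(=O)C(C)c3ccc(NS(C)(=O)=O)c(F)c3)CC2)cc1` keeps the aromatic ring and alters only its substituent: 4-methoxyphenyl in place of 3-methylphenyl on an amine nitrogen in a ring. Going by the values given here, no measured step tests a methoxy group here, but the step from compound 2 to compound 3 suggests substituent changes on this ring are small. The expected step is a 1.4-fold higher number from compound 3 to compound 4 (0.14 log units; within the scatter), within the scatter. Compound 4 is estimated at 2.5 nM, range 1 nM to 6.5 nM.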

Compound 4, inhibition constant: 1.6 nM
For compound 4 the middle estimate is 1.6-fold (0.19 log units) above the measured one, and the stated range covers the measured number.
By their numbers in this assay, from the lowest: compounds 4, 3 and 2 (each within the scatter of the next); then compound 1.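

The 4-methoxyphenyl group carries an oxygen into the ring on the amine nitrogen, yet in this assay swapping it for 3-methylphenyl gives a 1.1-fold lower number from compound 3 to compound 4 (0.05 log units; within the scatter) and setting it against plain phenyl gives a 1.3-fold lower number from compound 2 to compound 4 (0.10 log units; within the scatter) with no shift beyond the scatter. The separation from the cyclohexyl compound holds, at an 8.6-fold lower number from compound 1 to compound 4 (0.94 log units; beyond the scatter) for this aromatic ring. No evidence bears on why this ring tolerates both substituents.

Still open, on these data alone, is whether a carboxylic acid or an amine on this ring would shift the number beyond the scatter.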